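A few compounds are considered here, and "the series" means these few. Any claim that something is new, unique, unknown or untested is made for them only; others in the source may bear on it.

In a functional assay on brain (Rattus norvegicus, strain Wistar) for inhibition (a lower number here means a stronger inhibitor, a higher number a weaker inhibitor), three compounds built on a shared core have been measured. Compound 1 (`CCCCOc1ccc(-c2c(C)[nH]c(=O)n2C2CCCCC2)cc1`) gives 13900 nM and compound 2 (`CCCCc1ccc(-c2c(C)[nH]c(=O)n2-c2ccccc2)cc1`) gives 16600 nM, two values within the scatter of each other. Compound 3 (`COc1ccc(-c2c(C)[nH]c(=O)n2C)cc1`) gives 147000 nM, the highest of the three numbers and beyond the scatter from both others, which makes it the weakest inhibitor of the set. Compound 4 (`CCCCCCc1ccc(-c2c(C)[nH]c(=O)n2C)cc1`) differs from compound 3 in one place, with hexyl in place of methoxy on an aromatic carbon, para to a group of 8 heavy atoms (hexyl in place of methoxy on an aromatic carbon). Among the compounds with values here, no measured pair isolates this change. The lower numbers of compound 1 at 13900 nM and compound 2 at 16600 nM come with longer chains, but also with a ring where compound 3 has methyl, so only part of that gap is expected to carry over. The expected result is a 3.7-fold lower number from compound 3 to compound 4 (0.57 log units; beyond the scatter), a moderate move towards stronger inhibition. For compound 4 the estimate is 40000 nM, with an expected range of 12000 nM to 120000 nM.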

Compound 4, half-maximal inhibitory concentration: 9000 nM
Compound 4: middle estimate off by 4.4-fold (0.65 log units), on the high side; measured number outside the range, below it.
By their numbers in this assay, from the lowest: compounds 4, 1 and 2 (each within the scatter of the next); then compound 3.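

In this assay the swap of methoxy for hexyl on an aromatic carbon, para to a group of 8 heavy atoms, gives a 16-fold lower number from compound 3 to compound 4 (1.21 log units; beyond the scatter) and so counts as a large step made in one place. Until now longer chains had appeared only together with a ring where compound 3 has methyl, whereas this step shows that a change at this position alone, with that methyl kept, moves the number substantially. Nothing measured on hand explains the step.

Because hexyl differs from methoxy both in length and in lacking the oxygen, the compounds shown cannot say which of the two matters; butyl, butoxy or hexyloxy at this position would separate them. From the compounds shown here alone, it also remains open whether a longer chain such as octyl, or a chain ending in an amine, would keep the step.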